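Swapping a Bromophenyl Arm for a Methoxyphenyl Arm

This account rests on a few compounds, and the source may have more. Where it says the series, first, only, none or still open, it means among the compounds named here.

Of the compounds shown here, three that share one core have been tested in a functional assay on PC-3 cells (Homo sapiens) for inhibition, read by sulforhodamine B assay, with a stated time of 48 h, tested at 10 uM; on this read-out higher numbers stand for more inhibition at the one concentration tested (going by the name of the read-out) and lower numbers for less inhibition. Compound 1 `Brc1cn2ccnc2c(-c2ccc3ncn(C4CCCCC4)c3c2)n1` gives 17.2%. Compound 2 `c1cn2cc(-c3ccsc3)nc(-c3ccc4ncn(C5CCCCC5)c4c3)c2n1` gives 19.9%. Compound 3 `Brc1ccc(-c2cn3ccnc3c(-c3ccc4ncn(C5CCCCC5)c4c3)n2)cc1` gives 42.4%, the highest of the three numbers: the step of a number 25.2 percentage points higher from compound 1 to compound 3 (beyond the scatter) and the step of a number 22.5 percentage points higher from compound 2 to compound 3 (beyond the scatter) both lie beyond the scatter, while a number 2.7 percentage points higher from compound 1 to compound 2 (within the scatter) lies within it.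

Compound 4 `COc1ccccc1-c1cn2ccnc2c(-c2ccc3ncn(C4CCCCC4)c3c2)n1` has not yet been measured. It differs from compound 3 in one place: 2-methoxyphenyl in place of 4-bromophenyl on an aromatic carbon. The two measured steps that lead to compound 3 bear on this change, since each ends with a six-membered aromatic ring of carbon only at this place, and each was modest. No measured step compares two such rings with one another, so the direction of this change is not shown. Compound 4 keeps a six-membered aromatic ring of carbon only, so a step of about a number 4.4 percentage points lower from compound 3 to compound 4 (within the scatter) is expected, and compound 4 is estimated at 38%, with a range from 18% to 58%.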

Compound 4, a percentage reported as inhibition, at one concentration (the size of the read-out at that concentration, not a potency): 43.1%
Compound 4: the middle estimate sits 5.1 percentage points below what was measured; the measured number falls inside the stated range.
By their numbers in this assay, from the lowest: compounds 1 and 2 (each within the scatter of the next); then compounds 3 and 4 (each within the scatter of the next).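

Among these compounds, the step of a number 0.7 percentage points higher from compound 3 to compound 4 (within the scatter) is the first comparison of two six-membered aromatic rings of carbon only at this position, and it does not separate 2-methoxyphenyl from 4-bromophenyl, even though 2-methoxyphenyl brings one hydrogen-bond acceptor and 4-bromophenyl none. With the steps of a number 23.2 percentage points higher from compound 2 to compound 4 (beyond the scatter) and a number 25.9 percentage points higher from compound 1 to compound 4 (beyond the scatter) in view, a second such ring now stands clear of both thiophen-3-yl and bromo, so the gain over those two groups no longer rests on 4-bromophenyl alone. Nothing available explains why these groups give these numbers.

Still open, from the compounds shown here alone, is whether any ring of this kind can go clearly higher, since only two have been compared here. A phenyl ring carrying an amine or a carboxylic acid, or a pyridine ring in the same place, could begin to answer that.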